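Cytotoxicity of a carbohydrazide analogue of compound 3

This account rests on a few compounds, and the source may have more. Where it says the series, first, only, none or still open, it means among the compounds named here.

Among the measured compounds shown here, compound 3, `NC(=S)c1cn(COCCO)c2ncnc(N)c12`, is the only member of this small set with an actual number in an ADME assay (Fibroblast) for cytotoxicity, with Homo sapiens as the target; on this read-out higher numbers stand for weaker inhibition and lower numbers for stronger inhibition: compound 3 gives 100000 nM. Its two relatives reach only the edge of the measurement. Compound 1, `Nc1ncnc2c1ccn2COCCO`, is recorded in this assay as the limit > 100000 nM. Compound 2, `N#Cc1cn(COCCO)c2ncnc(N)c12`, is likewise recorded in this assay as the limit > 100000 nM. For the measured compounds named here, the change from compound 1 to compound 2 is a step that the two limits leave unreadable from compound 1 to compound 2, and both steps into compound 3 read as a number no higher from compound 1 to compound 3 (the limit leaves the size open) and a number no higher from compound 2 to compound 3 (the limit leaves the size open), so none of the measured steps has a readable size, as the limit of > 100000 nM in this assay, at which 2 of the 3 values shown sit, shows.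

Compound 4, `NNC(=O)c1cn(COCCO)c2ncnc(N)c12`, differs from compound 3 by a group of 4 heavy atoms (1 carbon, 2 nitrogen, 1 oxygen; no ring) in place of a group of 3 heavy atoms (1 carbon, 1 nitrogen, 1 sulfur; no ring), on an aromatic carbon. Going by the values given here, no measured step involves the group that enters, and the steps that involve the group that leaves are unreadable. The expectation for compound 4 is therefore simply that it stays where the whole series sits, with a step of about no change at the digits printed from compound 3 to compound 4 (within the scatter) in this assay that is expected to fall within the scatter. Compound 4 is estimated in this assay at 100000 nM, within a range from 40000 nM to 250000 nM, and it is quite possible that only a limit will be reported.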

Compound 4, half-maximal inhibitory concentration: > 100000 nM
Compound 4 ended at the assay's limit (the forecaster's own chance of this, stated with the estimate: 60%); the middle value sits exactly at the limit.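

In this assay, putting aminocarbamoyl on this aromatic carbon gives a number no lower from compound 3 to compound 4 (the limit leaves the size open), so this group does not bring the number below that of compound 3. Aminocarbamoyl thus joins the nitrile of compound 2 and the hydrogen of compound 1 as a third group at this position that ends at the assay's limit, and compound 3 remains the only one with an actual number. The steps that link compound 4 to compound 1 and to compound 2 cannot be read, because each of these pairs consists of two limits rather than two numbers: the limit of > 100000 nM in this assay, at which 3 of the 4 values shown sit.

Going by these compounds, it remains open whether the sulfur of compound 3 matters, which a plain carboxamide at this position could test, and whether an amine, a carboxylic acid or a longer chain on this carbon would give a clearly lower number. The compounds shown also leave open what would happen if the (2-hydroxyethoxy)methyl group were changed, since it stays the same throughout.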